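Swapping the aryl group on the sulfonate of compound 1

The source may report more compounds than this note shows. Statements on the series, on what has been measured and on what is new or still open speak of the compounds shown alone.

Of the compounds shown here, two of a shared core have been tested in a functional assay on MCF7 cells (Homo sapiens) for inhibition, read by MTT assay, with a stated time of 72 h; a lower number here means a stronger inhibitor, a higher number a weaker inhibitor. Compound 1, with the structure `O=C(O)CCCCCCC(=O)Nc1ccc(C2=C(c3ccc(O)cc3)C3CC(S(=O)(=O)Oc4ccc(C(F)(F)F)cc4)C2O3)cc1`, gives 24000 nM in this assay and carries the higher of the two numbers. Compound 2, with the structure `O=C(CCCCCCC(=O)Nc1ccc(C2=C(c3ccc(O)cc3)C3CC(S(=O)(=O)Oc4ccc(Br)cc4)C2O3)cc1)NO`, gives 17100 nM in this assay; the two values sit within the scatter of each other, so neither can be called the stronger inhibitor, and compound 2 differs from compound 1 in more than one place, so the pair teaches little about any single change.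

Compound 3, with the structure `Cc1ccccc1OS(=O)(=O)C1CC2OC1C(c1ccc(NC(=O)CCCCCCC(=O)O)cc1)=C2c1ccc(O)cc1`, has not yet been measured. It differs from compound 1 in one place: 2-methylphenyl in place of 4-(trifluoromethyl)phenyl on an oxygen. Going by the values given here, no measured pair shows what such a change does here, so the only anchor is the value of compound 1 itself. The step from compound 1 to compound 3 in this assay is expected to be small, a 1.0-fold higher number from compound 1 to compound 3 (0.02 log units; within the scatter), with no direction beyond the scatter. Compound 3 is therefore estimated to give 25000 nM in this assay, within a range from 10000 nM to 60000 nM.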

Compound 3, half-maximal inhibitory concentration: 7900 nM
For compound 3 the middle estimate is 3.2-fold (0.50 log units) above the measured one; measured number outside the range, below it.
By their numbers in this assay, from the lowest: compound 3; then compounds 2 and 1 (each within the scatter of the next).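

Going by these compounds alone, compound 1's aryl group on the sulfonate oxygen is not a silent part of the structure: in this assay, replacing 4-(trifluoromethyl)phenyl with 2-methylphenyl gives a 3.0-fold lower number from compound 1 to compound 3 (0.48 log units; beyond the scatter) and so provides the first single change here whose effect can be read beyond the scatter. Both groups contain one six-membered aromatic ring of carbon only, with no hydrogen-bond donors or acceptors and no net charge, but the swap changes the substituent on that ring and, as the two names show, its numbered place as well. No measurement shown here explains why the number falls.

This single step cannot separate the change of substituent from the change of place: 4-methylphenyl and 2-(trifluoromethyl)phenyl would each alter only one of the two, and plain phenyl would show the effect of having no substituent at all. Going by these compounds, it also remains open whether 2-methylphenyl would lower the number in the same way on a compound carrying the chain end of compound 2, or whether a pyridine ring at this position would keep the gain.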